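Catechol in place of methoxy on the bis-benzylidene core

The source may report more compounds than this note shows. Statements on the series, on what has been measured and on what is new or still open speak of the compounds shown alone.

Measured so far:
compound 1 `COc1ccc(/C=C2\CCC/C(=C\c3cccc(OC)c3OC)C2=O)cc1`: 18600 nM
compound 2 `COc1ccc(/C=C2\CCC/C(=C\c3cccc(OC)c3OC)C2=O)c(OC)c1`: > 20000 nM

Within the data shown here, in a functional assay on MCF7 cells (Homo sapiens) for cytotoxicity, read by MTT assay, with a stated time of 72 h (a lower number here means a stronger inhibitor, a higher number a weaker inhibitor), compound 1 gives 18600 nM and is the only compound with a number rather than a limit. Among the measured compounds shown here, compound 2 reports only a limit, > 20000 nM, the one value at the limit of > 20000 nM in this assay, at which 1 of the 2 values shown sits. For the measured compounds named here, the single measured step, an at least 1.0-fold higher number from compound 1 to compound 2 (0.03 log units; that floor lies within the scatter), concerns the other ring and says little about the change to compound 3 `COc1cccc(/C=C2\CCC/C(=C\c3ccc(O)c(O)c3)C2=O)c1OC`, namely (3,4-dihydroxyphenyl in place of 4-methoxyphenyl on a double-bonded chain carbon bound to a double-bonded ring carbon). Going by the values given here, no measured step bears on this change, so no shift beyond the scatter is expected, a 1.2-fold lower number from compound 1 to compound 3 (0.09 log units; within the scatter). Compound 3 is expected at 15000 nM (range 5000 nM to 40000 nM).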

Compound 3, half-maximal inhibitory concentration: 4700 nM
Compound 3: middle estimate off by 3.2-fold (0.50 log units), on the high side; measured number outside the range, below it.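

In this assay, this place on a double-bonded chain carbon bound to a double-bonded ring carbon responds to a change of ring substituents: 3,4-dihydroxyphenyl in place of 4-methoxyphenyl gives a 4.0-fold lower number from compound 1 to compound 3 (0.60 log units; beyond the scatter). Among these compounds, the earlier step, an at least 1.0-fold higher number from compound 1 to compound 2 (0.03 log units; that floor lies within the scatter), showed no readable movement, so this is the first shift beyond the scatter. Nothing measured here accounts for it. As far as these compounds go, whether a single hydroxyl group would carry the same step remains open, as does how an amine or a carboxylic acid would read at this place.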